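Working notes: substituent on the amine nitrogen of the shared core

The compounds below may be only part of what the source reports. "The series", "measured", "known", "first", "only" and "open" are said of these compounds alone.

Measured so far:
compound 1, `CCOC(=O)C1=C(N/N=C(/Br)c2ccccc2)Nc2[nH]nc(C)c2C1c1ccc(N(C)C)cc1`, 72000 nM
compound 2, `CCOC(=O)C1=C(N/C=N/c2cccnc2Cl)Nc2[nH]nc(C)c2C1c1ccc(N(C)C)cc1`, 4890 nM
compound 3, `CCOC(=O)C1=C(N/C=N/c2ccccn2)Nc2[nH]nc(C)c2C1c1ccc(N(C)C)cc1`, 26200 nM

All three share one core and differ only in the group carried on an amine nitrogen. In a functional assay on HepG2 cells (Homo sapiens) for inhibition, read by MTT assay, with a stated time of 48 h (on this read-out higher numbers stand for weaker inhibition and lower numbers for stronger inhibition), compound 3 stands second highest of the three numbers: compound 1 sits above it, a 2.7-fold lower number from compound 1 to compound 3 (0.44 log units; beyond the scatter), and compound 2 sits below it, a 5.4-fold higher number from compound 2 to compound 3 (0.73 log units; beyond the scatter). The widest spread seen so far is a 15-fold lower number from compound 1 to compound 2 (1.17 log units; beyond the scatter).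

Compound 4, `CCOC(=O)C1=C(N/N=C(\C#N)C(N)=O)Nc2[nH]nc(C)c2C1c1ccc(N(C)C)cc1`, is not yet measured. It differs from compound 3 in this way: a group of 7 heavy atoms (3 carbon, 3 nitrogen, 1 oxygen; no ring) in place of a group of 8 heavy atoms (6 carbon, 2 nitrogen; one six-membered aromatic ring with 1 hetero atom), on an amine nitrogen. For the measured compounds named here, the steps that bear on it are the two that change the group on the same amine nitrogen, a 2.7-fold lower number from compound 1 to compound 3 (0.44 log units; beyond the scatter) and a 5.4-fold higher number from compound 2 to compound 3 (0.73 log units; beyond the scatter), both modest; neither puts a group without a ring there, so the new change lies outside what has been tried. The expectation is therefore a modest step in this assay with no settled direction, and the estimate for compound 4 is 20000 nM, in the range 5000 nM to 80000 nM, which is expected to mean a 1.3-fold lower number from compound 3 to compound 4 (0.12 log units; within the scatter).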

Compound 4, half-maximal inhibitory concentration: 48400 nM
For compound 4 the middle estimate is 2.4-fold (0.38 log units) below the measured one; measured number inside the range.
By their numbers in this assay, from the lowest: compound 2; then compounds 3, 4 and 1 (each within the scatter of the next, the first and the last beyond it).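

In this assay, compound 4 shows that the group on the amine nitrogen need not hold a ring for the number to stay level with the ring-bearing groups of compounds 1 and 3: the readings are a 1.8-fold higher number from compound 3 to compound 4 (0.27 log units; within the scatter) and a 1.5-fold lower number from compound 1 to compound 4 (0.17 log units; within the scatter) and both lie within the scatter. Compound 2 remains apart from this new group as well, with a 9.9-fold higher number from compound 2 to compound 4 (1.00 log units; beyond the scatter) beyond the scatter, so among the groups shown at this position only 2-chloropyridin-3-yl gives a number clearly separated from all the others, and the open-chain group with its nitrile and amide does not approach it. No measurement at hand explains these numbers or the separation of compound 2.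

The shown compounds do not separate the chlorine of compound 2 from the attachment of its pyridine ring, since both differ from the pyridin-2-yl of compound 3, so a plain pyridin-3-yl group would be the telling comparison. Also open, as far as these compounds go, is how a carboxylic acid in place of the amide of compound 4, or a simple alkyl chain on this nitrogen, would read in this assay against these four compounds.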